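Compound 2 and the step from methyl to ethyl

The source may hold more compounds than are shown below. What is called first, only, known or untested is meant among the compounds shown, and "the series" means these compounds.

In an ADME assay on microsomes from liver (Macaca fascicularis) for metabolic stability, read by LC-MS, with a stated time of 65 min, tested at 1 uM (on this read-out higher numbers stand for a more stable compound and lower numbers for a less stable compound), compound 1 (`Fc1cc2nc(-c3cncnc3)n(C3CC3)c2cc1F`) gives 98% and compound 2 (`Cc1ncncc1-c1nc2cc(F)c(F)cc2n1C1CC1`) gives 72% as the lower of the two numbers. Compound 3 (`CCc1ncncc1-c1nc2cc(F)c(F)cc2n1C1CC1`) follows from compound 2 by methyl in place of hydrogen on a saturated chain carbon bound to an aromatic carbon in the form of methyl in place of hydrogen on a saturated chain carbon bound to an aromatic carbon. Within the data shown here, only one measured step bears on this, a modest one: a number 26 percentage points lower from compound 1 to compound 2 (beyond the scatter) for methyl in place of hydrogen on an aromatic carbon. A smaller move in the same direction is therefore expected, an estimated a number 14 percentage points lower from compound 2 to compound 3 (beyond the scatter) on this evidence. The expected value for compound 3 is 58% (estimated range 38% to 75%).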

Compound 3, percent of the compound remaining: 78%
For compound 3 the middle estimate is 20 percentage points below the measured one; the measured number lies above the stated range.
By their numbers in this assay, from the lowest: compounds 2 and 3 (each within the scatter of the next); then compound 1.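

In this assay, going from methyl to ethyl gives a number 6 percentage points higher from compound 2 to compound 3 (within the scatter), so the read-out does not separate these two groups at this place. Set against the compound with hydrogen on the aromatic carbon, ethyl gives a number 20 percentage points lower from compound 1 to compound 3 (beyond the scatter), a gap beyond the scatter, as the gap for methyl also was. Nothing measured here offers an explanation for these numbers.

As far as these compounds go, whether a longer chain such as propyl would stay within the scatter of compound 3 remains open. So does what an amine would give on that aromatic carbon.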